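Anilide Substituent Swap: Chloro Gives Way to Isopropyl

A few compounds are considered here, and "the series" means these few. Any claim that something is new, unique, unknown or untested is made for them only; others in the source may bear on it.

Two compounds have been measured so far in a functional assay on cells (Splenocyte, Mus musculus, strain BALB/c) for inhibition, read by MTT assay, with a stated time of 48 h; on this read-out lower numbers stand for stronger inhibition and higher numbers for weaker inhibition:

Compound 1, `CO/C(=C\c1ccccc1)C(=O)Nc1ccc(F)cc1`, gives 4940 nM.
Compound 2, `CO/C(=C\c1ccccc1)C(=O)Nc1ccc(Cl)cc1`, gives 17000 nM.

Within the data shown here, compound 2 stands at the higher of the two numbers; its only neighbour is compound 1, and the step of a 3.4-fold higher number from compound 1 to compound 2 (0.54 log units; beyond the scatter) lies beyond the usual scatter, so compound 2 is the weaker inhibitor of the pair. The unmeasured compound 3, `CO/C(=C\c1ccccc1)C(=O)Nc1ccc(C(C)C)cc1`, alters a single point of the shared core: isopropyl in place of chloro on an aromatic carbon. Among the measured compounds shown here, only one measured step bears on this, and only loosely: it shows that swapping one small group for another on this aromatic carbon moved the number by a 3.4-fold higher number from compound 1 to compound 2 (0.54 log units; beyond the scatter), so the position is sensitive to what sits there. As far as these compounds go, nothing measured, however, tells which way the isopropyl group will push the number, and a larger group here is untested. The expectation is therefore a modest further increase at most, wrapped in wide uncertainty. Compound 3 is estimated at 22000 nM, within 6000 nM to 70000 nM, which means an expected step of a 1.3-fold higher number from compound 2 to compound 3 (0.11 log units; within the scatter).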

Compound 3, half-maximal inhibitory concentration: 3460 nM
Beside the measured number, compound 3's estimate is 6.4-fold (0.80 log units) above it; the measured number lies below the stated range.
By their numbers in this assay, from the lowest: compounds 3 and 1 (each within the scatter of the next); then compound 2.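

In this assay, isopropyl in place of chloro on this aromatic carbon brings a 4.9-fold lower number from compound 2 to compound 3 (0.69 log units; beyond the scatter), so the position accepts a group of 3 heavy atoms, which the earlier pair, each carrying a single heavy atom here, could not show. Isopropyl in place of fluoro gives a 1.4-fold lower number from compound 1 to compound 3 (0.15 log units; within the scatter), which leaves these two compounds level, and compound 2 is the weakest inhibitor of the three, with both of its steps beyond the scatter. The numbers therefore do not climb steadily along the series fluoro, chloro, isopropyl: compound 2 rises above compound 1, while compound 3 goes against any such trend by returning to the level of compound 1. Nothing available explains why the chloro compound stands apart from the other two. The compounds shown leave open whether other groups on this same carbon, such as an amine, a methoxy group or a carboxylic acid, would fall with compound 2 or with compounds 1 and 3. They also leave open whether a longer chain or a tert-butyl group here would hold the number at the level of compound 3 or shift it.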